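This account rests on a few compounds, and the source may have more. Where it says the series, first, only, none or still open, it means among the compounds named here.

Measured in an assay on cells for inhibition of Amine oxidase [flavin-containing] B (Homo sapiens), read by fluorescence and Amplex Red, with stated times of 30 min and 15 min; a lower number here means a stronger inhibitor, a higher number a weaker inhibitor:
compound 1, `C#CCNC1CCc2c(NCc3ccc(F)cc3)cccc21`: compound 1 gives 980 nM
compound 2, `C#CCNC1CCc2c(NCc3ccc(C)cc3)cccc21`: compound 2 gives 250 nM
compound 3, `C#CCNC1CCc2c(OCCc3cc(NC(=O)c4ccccc4)ccc3Cl)cccc21`: compound 3 returns only a limit, > 20000 nM

Among the compounds with values here, compound 3 stands apart from the other two: its result is a bound of the assay and not a number, and it is the single value sitting at the limit of > 20000 nM in this assay, at which 1 of the 3 values shown sits. Within the data shown here, the only measured step, a 3.9-fold lower number from compound 1 to compound 2 (0.59 log units; beyond the scatter), concerns a change of a different kind and does not bear on the move to compound 4, `C#CCNC1CCc2c(OCCc3cc(NC(=O)CO)ccc3Cl)cccc21`, which carries hydroxymethyl in place of phenyl on a carbonyl carbon. Among the measured compounds shown here, no measured pair tests this change, so the expectation rests on compound 3 alone. Compound 4 is expected to remain weak, the step of a number no higher from compound 3 to compound 4 (the limit leaves the size open) meaning no change beyond the scatter, and its result may again be only a limit. The estimate for compound 4 is 20000 nM, with a range from 5000 nM to 80000 nM.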

Compound 4, half-maximal inhibitory concentration: 270 nM
Compound 4: the middle estimate sits 74-fold (1.87 log units) above what was measured, outside the stated range (below it).
By their numbers in this assay, from the lowest: compounds 2 and 4 (each within the scatter of the next); then compound 1. At a limit, above all of these: compound 3.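

In this assay, the group on the carbonyl carbon of the amide strongly affects the result: hydroxymethyl in place of phenyl gives an at least 74-fold lower number from compound 3 to compound 4 (1.86 log units; beyond the scatter). Within the data shown here, this is the first measured change at this position, and it shows that a small group with a hydrogen-bond donor is compatible with a measurable number here. The result for compound 3 is only a limit of the assay, so the full size of the step is unknown: the limit of > 20000 nM in this assay, at which 1 of the 4 values shown sits.

The change removes the aromatic ring and adds the hydroxyl at once, and the compounds shown do not separate these two effects. A methyl group or an aminomethyl group on the same carbonyl carbon would help to tell them apart.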